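Acid dissociation notes on a thienopyrimidinone amine series

The source may report more compounds than this note shows. Statements on the series, on what has been measured and on what is new or still open speak of the compounds shown alone.

Measured so far:
compound 1 `Cc1csc2cc([C@H](C)Nc3ncnc(N)c3C#N)c(-c3cccc(CN4CCC(N(C)CC(C)C)CC4)c3)c(=O)n12`: 9.7
compound 2 `Cc1csc2cc([C@H](C)Nc3ncnc(N)c3C#N)c(-c3cccc(CN(C)CCCCN(C)Cc4ccccc4)c3)c(=O)n12`: 9.1

In a physicochemical assay for acid dissociation, compound 1 gives 9.7, the higher of the two numbers; compound 2 gives 9.1, a gap beyond the scatter. Compound 3 `Cc1csc2cc([C@H](C)Nc3ncnc(N)c3C#N)c(-c3cccc(CN4CCC(CN(C)Cc5ccccn5)CC4)c3)c(=O)n12` is not yet measured. It differs from compound 1 in one place: (methyl((pyridin-2-yl)methyl)amino)methyl in place of isobutyl(methyl)amino on a saturated ring carbon. Among the measured compounds shown here, no step between measured compounds covers this change. Given the lower value of compound 2, a downward step from compound 1 to compound 3 of a number 0.50 log units lower from compound 1 to compound 3 (beyond the scatter) is expected. Compound 3 is estimated at 9.2, within 8.6 to 9.8.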

Compound 3, acid dissociation constant: 9
Estimate against measurement, compound 3: 0.20 log units above, within the range that was stated.
By their numbers in this assay, from the lowest: compounds 3 and 2 (each within the scatter of the next); then compound 1.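

In this assay, the saturated ring carbon three ring bonds from the ring nitrogen responds to substitution: (methyl((pyridin-2-yl)methyl)amino)methyl in place of isobutyl(methyl)amino gives a number 0.70 log units lower from compound 1 to compound 3 (beyond the scatter) at this position. Among the compounds shown here, this is the first step that ties a change in the read-out to one place. Nothing at hand accounts for the size of this step.

The change brings in the pyridin-2-yl ring and a longer link together, and the two remain unseparated. A simple dimethylamino group at the same ring carbon would be a further point of comparison.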